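The source may hold more compounds than are shown below. What is called first, only, known or untested is meant among the compounds shown, and "the series" means these compounds.

Measured in an in vivo ADME assay on the whole organism (Cavia porcellus); a lower number here means that the compound disappears faster, a higher number that the compound lasts longer
compound 1 `CCC(NC(=O)c1ccc(C(=N)N)cc1)C(C)(C)C(=O)N1CCC(CC(=O)O)CC1` gives 1.3 h
compound 2 `C/C=C/C(NC(=O)c1ccc(C(=N)N)cc1)C(C)(C)C(=O)N1CCC(CC(=O)O)CC1` gives 0.933 h
compound 3 `CC(C)(C(=O)N1CCC(CC(=O)O)CC1)C(NC(=O)c1ccc(C(=N)N)cc1)c1ccc2ccccc2c1` gives 0.85 h

Compound 2 lies within the scatter of both other compounds, with a 1.4-fold lower number from compound 1 to compound 2 (0.14 log units; within the scatter) and a 1.1-fold lower number from compound 2 to compound 3 (0.04 log units; within the scatter) as its two steps, so the three numbers show no order. Next in the series is compound 4 `CC(C)(C(=O)N1CCC(CC(=O)O)CC1)C(NC(=O)c1ccc(C(=N)N)cc1)c1cccc(Cl)c1` with 3-chlorophenyl in place of prop-1-en-1-yl on a saturated chain carbon bound to an amide-type nitrogen and a saturated chain carbon in this assay still to be measured. The change puts 3-chlorophenyl in place of prop-1-en-1-yl on a saturated chain carbon bound to an amide-type nitrogen and a saturated chain carbon. The closest guide is compound 3, where naphthalen-2-yl enters at the same place, giving a 1.1-fold lower number from compound 2 to compound 3 (0.04 log units; within the scatter) as the step. Replacing ethyl at that place gave a 1.4-fold lower number from compound 1 to compound 2 (0.14 log units; within the scatter) and a 1.5-fold lower number from compound 1 to compound 3 (0.18 log units; within the scatter) as steps, both also within the scatter. For the measured compounds named here, no measured compound carries 3-chlorophenyl, so this rests on analogy alone. No step beyond the scatter is expected, and the estimated step is a 1.0-fold lower number from compound 2 to compound 4 (0.02 log units; within the scatter) in size. The estimate for compound 4 is 0.9 h with an expected range from 0.55 h to 1.4 h in this read-out.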

Compound 4, half-life: 2.5 h
Compound 4: the middle estimate sits 2.8-fold (0.44 log units) below what was measured, outside the stated range (above it).
By their numbers in this assay, from the lowest: compounds 3, 2, 1 and 4 (each within the scatter of the next, the first and the last beyond it).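

In this assay, for the compounds shown here, the position on a saturated chain carbon bound to an amide-type nitrogen and a saturated chain carbon now gives steps beyond the scatter, which the earlier compounds did not show: 3-chlorophenyl in place of prop-1-en-1-yl gives (a 2.7-fold higher number from compound 2 to compound 4 (0.43 log units; beyond the scatter)) and 3-chlorophenyl in place of naphthalen-2-yl gives (a 2.9-fold higher number from compound 3 to compound 4 (0.47 log units; beyond the scatter)). The presence of an aromatic ring at this place therefore does not alone set the half-life, since these two aromatic groups are separated by a step beyond the scatter, while 3-chlorophenyl in place of ethyl stays within it (a 1.9-fold higher number from compound 1 to compound 4 (0.28 log units; within the scatter)). Nothing available on these compounds explains the difference.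

The compounds shown leave open whether the chlorine or the phenyl ring carries the step, which a plain phenyl group would test. A cyclohexyl group at the same place would show whether an aromatic ring is needed at all.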